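Replacing the sulfanyl ester chain of compound 1

This account rests on a few compounds, and the source may have more. Where it says the series, first, only, none or still open, it means among the compounds named here.

Measured in a functional assay on the whole organism (strain Hartley) for inhibition, with Cavia porcellus as the target, with stated times of 15 min and 2 min; a higher number here means that more compound is needed for the effect, a lower number that less compound is needed:
Compound 1 `CCCCC1([C@H](O)/C=C/C2CCC(=O)[C@@H]2CCCCSCC(=O)OCC)CCC1`: 0.03 mg/kg
Compound 2 `CCCCC1([C@@H](O)/C=C/C2CCC(=O)[C@@H]2CCCCSCC(=O)OCC)CCC1`: > 0.672 mg/kg (a limit of the assay)

In this assay, within the data shown here, compound 1 holds the only actual number so far, 0.03 mg/kg. Among the measured compounds shown here, the sole comparison, compound 2, gives > 0.672 mg/kg, and this is a limit and not a number. The step between them is an at least 22-fold higher number from compound 1 to compound 2 (1.35 log units; beyond the scatter). It concerns a stereocentre at a saturated chain carbon, not the group changed next, so it shows only that this assay can respond strongly to a single structural difference in this series.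

Compound 3 `CCCCC1([C@H](O)/C=C/C2CCC(=O)[C@@H]2CCCCCCCCC(=O)OCC)CCC1` differs from compound 1 as follows: 4-(ethoxycarbonyl)butyl in place of ((ethoxycarbonyl)methyl)sulfanyl on a saturated chain carbon, four bonds along the chain from a saturated ring carbon. The group 4-(ethoxycarbonyl)butyl thus takes the place of ((ethoxycarbonyl)methyl)sulfanyl, on a saturated chain carbon, four bonds along the chain from a saturated ring carbon. For the measured compounds named here, no measured step covers this change, so the expectation is uncertain. Starting from compound 1 at 0.03 mg/kg, a moderate rise in this assay is expected rather than no change. The expected step is a 3.3-fold higher number from compound 1 to compound 3 (0.52 log units; beyond the scatter). For compound 3 the estimate is 0.1 mg/kg, with an expected range from 0.02 mg/kg to 0.6 mg/kg.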

Compound 3, dose for half-maximal effect: 6.21 mg/kg
Beside the measured number, compound 3's estimate is 62-fold (1.79 log units) below it; the whole stated range lies below it.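

Compound 1 carries ((ethoxycarbonyl)methyl)sulfanyl on a saturated chain carbon, four bonds along the chain from a saturated ring carbon, and in this assay putting 4-(ethoxycarbonyl)butyl there gives a 210-fold higher number from compound 1 to compound 3 (2.32 log units; beyond the scatter), a large step. The earlier compounds shown here showed a strong response only to a stereocentre, whereas this result shows that the same assay also responds strongly to a change in the make-up of the chain, with the configuration drawn as in compound 1 kept. Nothing in the evidence at hand bears on this step, so the data offer no explanation for its size.

The group that enters carries no sulfur and has more heavy atoms than the group that leaves, so this one step cannot tell whether the loss of sulfur, the larger group or both together set the result. On these data alone, how a chain with an oxygen atom in place of the sulfur, or one with a carboxylic acid in place of the ethyl ester, would stand in this assay remains open.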